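Urea in place of acetamide on a pyrrolidine amide series

The compounds below may be only part of what the source reports. "The series", "measured", "known", "first", "only" and "open" are said of these compounds alone.

The measured compounds:
Compound 1, `CC(C)(C)OC(=O)N1C(=O)CC[C@H]1C(=O)N1CCC(NS(=O)(=O)c2cc(S(=O)(=O)c3ccccc3)ccc2C(F)(F)F)CC1`: 90 nM
Compound 2, `CC(=O)N1CCC[C@H]1C(=O)N1CCC(NS(=O)(=O)c2cc(S(=O)(=O)c3ccccc3)ccc2C(F)(F)F)CC1`: 250 nM
Compound 3, `CN(C)c1ccc(C(=O)N2CCC[C@H]2C(=O)N2CCC(NS(=O)(=O)c3cc(S(=O)(=O)c4ccccc4)ccc3C(F)(F)F)CC2)cc1`: 830 nM

In a functional assay on U2OS cells for antagonist activity at proto-oncogene Wnt-3 (Homo sapiens), read by a luciferase reporter, with a stated time of 18 h (a lower number here means that less compound is needed, a higher number that more compound is needed for the effect), compound 2 stands second highest of the three numbers; compound 1 gives a lower number, and compound 3 a higher one, both beyond the scatter. The unmeasured compound 4, `O=C([C@@H]1CCCN1C(=O)Nc1ccccc1)N1CCC(NS(=O)(=O)c2cc(S(=O)(=O)c3ccccc3)ccc2C(F)(F)F)CC1`, is reached from compound 2 by the change (anilino in place of methyl on a carbonyl carbon). Among the measured compounds shown here, the only measured step that bears on this position is a 3.3-fold higher number from compound 2 to compound 3 (0.52 log units; beyond the scatter), where a larger group on the same carbonyl carbon raised the number. Compound 4 also carries a larger group there, though with a hydrogen-bond donor rather than a second aryl carbonyl, so a step in the same direction is expected, probably of modest size. On that basis the number for compound 4 in this assay is estimated at 450 nM, with a range from 150 nM to 1400 nM. This estimate means an expected step of a 1.8-fold higher number from compound 2 to compound 4 (0.26 log units; within the scatter).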

Compound 4, half-maximal effective concentration: 310 nM
The estimate for compound 4 lay 1.5-fold (0.16 log units) above the measured number, and the stated range covers the measured number.
By their numbers in this assay, from the lowest: compound 1; then compounds 2 and 4 (each within the scatter of the next); then compound 3.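

In this assay, a 1.2-fold higher number from compound 2 to compound 4 (0.09 log units; within the scatter) shows that placing anilino on this carbonyl carbon, with its six-membered aromatic ring and hydrogen-bond donor, leaves the number within the scatter of the methyl compound. The earlier 3.3-fold higher number from compound 2 to compound 3 (0.52 log units; beyond the scatter) therefore does not show a rise for every larger group here: a 2.7-fold lower number from compound 3 to compound 4 (0.43 log units; beyond the scatter) separates two aromatic groups at the same place, with compound 3 alone beyond the scatter of compound 2. No measurement offered here gives a reason for the difference between the anilino and 4-(dimethylamino)phenyl groups.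

The compounds shown leave open whether a plain phenyl on this carbonyl carbon would stand with compound 3 or compound 4. They also leave open whether methylamino, or N-methylanilino without the amide hydrogen, would keep the number of compound 4.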